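Adding a hydroxy group to compound 1

This account rests on a few compounds, and the source may have more. Where it says the series, first, only, none or still open, it means among the compounds named here.

Compound 1 `COc1ccc(-n2cnnc2-c2cc(OC)c(OC)c(OC)c2)cc1`: 373 nM
Compound 2 `COc1cc(-c2nncn2-c2ccc(N(C)C)cc2)cc(OC)c1OC`: 119 nM

In an ADME assay on KB 3-1 cells (Homo sapiens) for cytotoxicity (a lower number here means a stronger inhibitor, a higher number a weaker inhibitor), compound 1 gives the higher of the two numbers, 373 nM. Going by the values given here, the only measured step is a 3.1-fold lower number from compound 1 to compound 2 (0.50 log units; beyond the scatter), with dimethylamino in place of methoxy on an aromatic carbon. Compound 3 `COc1ccc(-n2cnnc2-c2cc(OC)c(OC)c(OC)c2)cc1O` is a different change to compound 1: hydroxy in place of hydrogen on an aromatic carbon. The measured step bears on it only indirectly, as it replaces a group rather than a hydrogen, but it shows that the number can move with a single change. The expected step, resting on that one precedent, is a 6.2-fold lower number from compound 1 to compound 3 (0.79 log units; beyond the scatter). For compound 3 the estimated value is 60 nM, with an expected range from 10 nM to 300 nM.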

Compound 3, half-maximal inhibitory concentration: 57.3 nM
Estimate against measurement, compound 3: 1.0-fold (0.02 log units) above; the range from low to high includes it.
By their numbers in this assay, from the lowest: compound 3; then compound 2; then compound 1.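

In this assay, hydroxy in place of hydrogen on an aromatic carbon, ortho to a methoxy group, gives a 6.5-fold lower number from compound 1 to compound 3 (0.81 log units; beyond the scatter) on the core of compound 1. This shows that the number can fall when a group is added to this ring at a position that held only hydrogen, not only when an existing group is replaced. Nothing available explains the change.

The compounds shown leave open whether an amine or a carboxylic acid at this position would lower the number as well. They also leave open whether the hydroxy group would have the same effect alongside the dimethylamino group of compound 2.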